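This account rests on a few compounds, and the source may have more. Where it says the series, first, only, none or still open, it means among the compounds named here.

Series notes. Compound 1 `CCNC(=O)C1CCN(c2nc(N)c3cc(OC)c(OC)cc3n2)CC1` gives 1.64 nM in an assay on isolated protein for displacement of a labelled ligand from Adrenergic receptor alpha-1 (Rattus norvegicus) (on this read-out higher numbers stand for weaker inhibition and lower numbers for stronger inhibition), which places it second highest of the three numbers in hand. Compound 2 `CCCCNC(=O)C1CCN(c2nc(N)c3cc(OC)c(OC)cc3n2)CC1` gives 0.67 nM in this assay, and compound 3 `CCCCNC(=O)C1CCCN(c2nc(N)c3cc(OC)c(OC)cc3n2)C1` gives 8.25 nM. The single-change step from the first pair is a 2.4-fold lower number from compound 1 to compound 2 (0.39 log units; beyond the scatter). Compound 3 differs from compound 1 in more than one place, so only its two values can be set side by side: the number of compound 3 is the highest of the three.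

Compound 4 `COc1cc2nc(N3CCC(C(=O)NC4CCCC4)CC3)nc(N)c2cc1OC` is not yet measured. Against compound 1 the change is cyclopentyl in place of ethyl on an amide-type nitrogen, a larger carbon-only group on the same amide-type nitrogen.

Among the compounds with values here, the one measured step that bears on this is the enlargement of the amide substituent, a 2.4-fold lower number from compound 1 to compound 2 (0.39 log units; beyond the scatter), which lowered the number beyond the scatter. Cyclopentyl is a further enlargement at the same place, though a ring rather than a chain, and no ring substituent on this nitrogen has been measured in the series. A step of similar size in the same direction is therefore expected, with a wide range. The expected step is a 2.1-fold lower number from compound 1 to compound 4 (0.31 log units; beyond the scatter). Compound 4 is expected to give 0.8 nM in this assay, within 0.3 nM to 2.5 nM.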

Compound 4, inhibition constant: 0.63 nM
Beside the measured number, compound 4's estimate is 1.3-fold (0.10 log units) above it; the range from low to high includes it.
By their numbers in this assay, from the lowest: compounds 4 and 2 (each within the scatter of the next); then compound 1; then compound 3.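

In this assay, a ring on the amide-type nitrogen is accepted: cyclopentyl in place of ethyl gives a 2.6-fold lower number from compound 1 to compound 4 (0.42 log units; beyond the scatter) and so goes the same way as the butyl group of compound 2, which until now was the only enlargement at this place. Cyclopentyl in place of butyl gives a 1.1-fold lower number from compound 2 to compound 4 (0.03 log units; within the scatter), so on this read-out the ring and the open chain cannot be told apart, and closing the carbons into a ring brings neither a gain nor a loss over butyl. The data in hand offer no measurement that would explain why either larger group differs from ethyl or why the two match each other.

Still open, as far as these compounds go, is whether the trend continues or levels off with a longer chain such as hexyl, a larger ring such as cyclohexyl, or an aromatic group such as benzyl, and whether an amine or a hydroxyl on the chain would be accepted at the same place. Also open, from the compounds shown here alone, is whether cyclopentyl would behave in the same way on the ring arrangement of compound 3 , which so far carries only butyl.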